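Fluoro-substituted aryl ureas: whole-organism activity notes

This account rests on a few compounds, and the source may have more. Where it says the series, first, only, none or still open, it means among the compounds named here.

In an ADME assay on the whole organism with Oryza sativa as the target, tested at 1 uM (a higher number here means a weaker effect of the compound at the concentration tested, a lower number a stronger effect), the measured compounds stand as follows:

compound 1 `C[C@@H](NC(=O)Nc1cccc(F)c1)c1ccccc1` gives 95%
compound 2 `C[C@H](NC(=O)Nc1cccc(F)c1)c1ccccc1` gives 94%
compound 3 `C[C@H](NC(=O)Nc1cccc(F)c1F)c1ccccc1` gives 100%

Compound 1 and compound 2 share all atoms and bonds: the two compounds have the same atoms and bonds and differ only in configuration as drawn: 1 of 1 stereo elements differ; a stereocentre at a saturated chain carbon is drawn S in compound 2 and R in compound 1. The step of a number 1 percentage points lower from compound 1 to compound 2 (within the scatter) lies within the scatter, in line with the fact that compounds 1 and 2 differ only in the configuration as drawn.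

Compound 3 differs from compound 2 by fluoro in place of hydrogen on an aromatic carbon, and the step is a number 6 percentage points higher from compound 2 to compound 3 (within the scatter).

Compound 4 `C[C@@H](NC(=O)Nc1cc(F)ccc1F)c1ccccc1` is not yet measured. It differs from compound 1 by fluoro in place of hydrogen on an aromatic carbon. The entering fluoro in compound 3 sits ortho to a fluoro group, in compound 4 para to a fluoro group, so this is the same kind of change, not the same one. The expected step is a number 3 percentage points higher from compound 1 to compound 4 (within the scatter), resting on a number 6 percentage points higher from compound 2 to compound 3 (within the scatter) made by the same kind of change. Compound 4 is therefore estimated at 98%, between 90% and 100%.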

Compound 4, a percentage reported as activity, at one concentration (the size of the read-out at that concentration, not a potency): 100%
Beside the measured number, compound 4's estimate is 2 percentage points below it; measured number inside the range.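

In this assay, fluoro in place of hydrogen on an aromatic carbon gives a number 5 percentage points higher from compound 1 to compound 4 (within the scatter), and the two cores agree on this change: the same change on two cores in this assay, a number 6 percentage points higher (within the scatter) from compound 2 to compound 3 and a number 5 percentage points higher (within the scatter) from compound 1 to compound 4, 1 percentage points apart, within the scatter of two such steps. The change therefore carries from one core to the other without a detectable difference, but each step lies within the scatter, so neither pair shows that the added fluoro has any effect in this assay. The entering fluoro also sits para to a fluoro group only in compound 4, and two pairs give no rule for other cores.

The compounds shown leave open whether a group other than fluoro on the aromatic ring, such as an amine or a carboxylic acid, would move the number beyond the scatter.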